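The compounds below may be only part of what the source reports. "The series", "measured", "known", "first", "only" and "open" are said of these compounds alone.

Among the measured compounds shown here, in a functional assay on HCT-116 cells (Homo sapiens) for cytotoxicity, read by MTT assay, with a stated time of 48 h, in the presence of a further agent that is not named here (on this read-out lower numbers stand for an effect already at smaller amounts and higher numbers for an effect only at larger amounts of compound), compound 2 (`CCN(CC)c1cc(NC(=O)NNc2cc(-c3ccc(F)cc3)c3cnn(C)c3n2)cc(Cl)n1`) gives 29400 nM, the lowest of the three numbers so far. Compound 3 (`Cc1nn(C)c2nc(NNC(=O)Nc3cc(Cl)nc(Cl)c3)cc(-c3ccco3)c12`) reads 69200 nM and compound 1 (`CCCc1cc(NNC(=O)Nc2cc(Cl)nc(Cl)c2)nc2c1c(C)nn2C`) reads 72200 nM, both higher than compound 2 by more than the usual scatter. Compound 4 (`COc1cc(NC(=O)NNc2cc(-c3ccc(F)cc3)c3cnn(C)c3n2)cc(Cl)n1`) departs from compound 2 in one place: methoxy in place of diethylamino on an aromatic carbon. For the measured compounds named here, no measured step covers this change. The only one available, a 1.0-fold lower number from compound 1 to compound 3 (0.02 log units; within the scatter), places furan-2-yl in place of propyl on an aromatic carbon, a different part of the molecule, and it stays within the scatter. The sole hint on direction is indirect: compound 1 at 72200 nM and compound 3 at 69200 nM lack the diethylamino group and read higher than compound 2, but they also differ from it in other places. A small move towards a higher number is therefore expected, held with little confidence. The expected step is a 1.4-fold higher number from compound 2 to compound 4 (0.13 log units; within the scatter). Compound 4 is estimated at 40000 nM, within an expected range of 17000 nM to 90000 nM.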

Compound 4, half-maximal effective concentration: 75300 nM
Compound 4: the middle estimate sits 1.9-fold (0.27 log units) below what was measured; the range from low to high includes it.
By their numbers in this assay, from the lowest: compound 2; then compounds 3, 1 and 4 (each within the scatter of the next).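

Methoxy in place of diethylamino gives a 2.6-fold higher number from compound 2 to compound 4 (0.41 log units; beyond the scatter) in this assay, and this is the first step among the compounds shown that lies beyond the scatter. It shows that the number responds to the group on this aromatic carbon, next to the ring nitrogen and meta to a chloro group, with the diethylamino group on the lower side of the pair. The exchange takes 5 heavy atoms down to 2 and leaves 1 hydrogen-bond acceptor on each side, but no measurement here accounts for the step.

Only these two groups are compared at this position, so size and the atom joined to the ring cannot be told apart. As far as these compounds go, it stays open whether an ethoxy group, which keeps the oxygen, or a dimethylamino group, which keeps the nitrogen, would read closer to compound 2 or to compound 4.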